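A few compounds are considered here, and "the series" means these few. Any claim that something is new, unique, unknown or untested is made for them only; others in the source may bear on it.

The account follows three compounds built on a shared core. Compound 1 `O=C(/C=C/c1ccc(O)cc1)c1c(O)cccc1OCCC1CCCC1` was tested in a functional assay on ACHN cells (Homo sapiens) for antiproliferative activity, read by sulforhodamine B assay (on this read-out higher numbers stand for weaker inhibition of growth and lower numbers for stronger inhibition of growth), and in this assay compound 1 gives 3400 nM. Compound 2 `CC(C)(C)CCOc1cccc(O)c1C(=O)CCc1ccc(O)cc1` was tested in the same way; in this assay compound 2 reaches only a limit of the assay, > 30000 nM. Among the compounds with values here, compound 1 thus holds the only real number among the values shown, while the other value is the limit of > 30000 nM in this assay, at which 1 of the 2 values shown sits. Within the data shown here, no two measured compounds differ in a single place, so no measured step can be traced, and the two values of compound 1 and compound 2 show only that one is a number and the other a limit.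

Compound 3 `O=C(/C=C/c1ccc(O)cc1)c1c(O)cccc1OCCC1CCCCC1` remains to be measured in this assay. It differs from compound 1 by cyclohexyl in place of cyclopentyl on a saturated chain carbon, two bonds along the chain from an oxygen on an aromatic ring. With nothing measured to guide the size of such a step, the author expects the step of a 1.1-fold lower number from compound 1 to compound 3 (0.05 log units; within the scatter) to stay within the usual scatter, in no particular direction. Compound 3 is accordingly estimated at about 3000 nM, with a likely range from 1200 nM to 8000 nM.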

Compound 3, concentration for 50% growth inhibition: > 30000 nM
Compound 3: no number, only a limit; the forecaster's own chance of this, stated with the estimate: 5%; at least 10-fold (1.00 log units) between middle value and limit.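

The result gives this position its first traced step: in this assay, cyclohexyl in place of cyclopentyl on a saturated chain carbon, two bonds along the chain from an oxygen on an aromatic ring, gives an at least 8.8-fold higher number from compound 1 to compound 3 (0.94 log units; beyond the scatter). Neither group carries hydrogen-bond donors, hydrogen-bond acceptors or a net charge, so this single exchange of a five-membered for a six-membered ring of carbon is enough to separate a measured number from a limit, and growth inhibition at this place proves sensitive to which carbon ring stands at the end of the chain. Compound 3 gives only a limit and no number, so the step marks a smallest size rather than a full size, and compound 3 now shares that limit with another compound: the limit of > 30000 nM in this assay, at which 2 of the 3 values shown sit.

On these data alone, how far the true value of compound 3 lies past its limit remains open, and so does the full size of the step. Also open, as far as these compounds go, is how growth inhibition would respond at this same place to a smaller ring such as cyclobutyl, to a longer chain carrying the cyclopentyl, or to an amine at the end of the chain.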